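The compounds below may be only part of what the source reports. "The series", "measured", "known", "first", "only" and "open" are said of these compounds alone.

Measured in a functional assay on U-87MG ATCC cells (Homo sapiens) for cytotoxicity, read by MTT assay, with a stated time of 48 h; a lower number here means a stronger inhibitor, a higher number a weaker inhibitor
- compound 1 `C/C(=N\NC(=S)Nc1ccc(Cl)cc1)c1ccccn1` gives 1.7 nM
- compound 2 `C/C(=N\NC(=S)Nc1ccc(I)cc1)c1ccccn1` gives 59 nM

Compound 1 holds the lower of the two numbers. Compound 3 `C/C(=N/NC(=S)Nc1ccc(Cl)cc1)c1ccccn1` is its configurational partner, and (the two compounds have the same atoms and bonds and differ only in configuration as drawn: 1 of 1 stereo elements differ; a double bond is drawn E in compound 1 and Z in compound 3). Going by the values given here, the only measured step, a 35-fold higher number from compound 1 to compound 2 (1.54 log units; beyond the scatter), concerns the halogen, so no measured pair tests the double bond. Among the compounds with values here, that step shows only that one small change can move the series far. A rise in the number is expected, though smaller than that halogen step, at an estimated 3.5-fold higher number from compound 1 to compound 3 (0.55 log units; beyond the scatter). For compound 3 the expected value is 6 nM, with an estimated range of 1.2 nM to 60 nM.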

Compound 3, half-maximal inhibitory concentration: 1.7 nM
For compound 3 the middle estimate is 3.5-fold (0.55 log units) above the measured one; the measured number falls inside the stated range.
By their numbers in this assay, from the lowest: compounds 1 and 3 (each within the scatter of the next); then compound 2.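

In this assay the double bond now has its own measured test, and the reading is no change at the digits printed from compound 1 to compound 3 (within the scatter). The pair isolates that single element: the fact that compounds 1 and 3 differ only in the configuration as drawn. Configuration as drawn thus leaves the number in place for the chloro pair, whereas the halogen change gave a 35-fold higher number from compound 1 to compound 2 (1.54 log units; beyond the scatter).

As far as these compounds go, whether the iodo compound behaves the same way at its double bond stays open. So does the response to a methoxy or a nitrile in place of the halogen, or to a carbonyl in place of the thiocarbonyl.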